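The source may report more compounds than this note shows. Statements on the series, on what has been measured and on what is new or still open speak of the compounds shown alone.

Measured so far in a functional assay on NCI-H460 cells (Homo sapiens) for inhibition, read by MTT assay; a higher number here means a weaker inhibitor, a lower number a stronger inhibitor:
- compound 1, `CCOC(=O)c1c(NC(=O)CC#N)sc(C(=O)Nc2ccc(Cl)cc2)c1-c1ccccc1`: 430 nM
- compound 2, `N#CCC(=O)Nc1sc(C(=O)Nc2ccc(Cl)cc2)c(-c2ccccc2)c1C#N`: 1040 nM
- compound 3, `CCOC(=O)c1c(NC(=O)CC#N)sc(C(=O)Nc2ccccc2)c1-c1ccccc1`: 490 nM

Compound 4, `N#CCC(=O)Nc1sc(C(=O)Nc2ccccc2)c(-c2ccccc2)c1C#N`, remains to be measured in this assay.

Within the measured set, compound 1 and compound 3 differ by hydrogen in place of chloro on an aromatic carbon, and the step of a 1.1-fold higher number from compound 1 to compound 3 (0.06 log units; within the scatter) shows that this swap on the carbamoyl ring does little. The change of interest is cyano in place of ethoxycarbonyl on an aromatic carbon, which gave a 2.4-fold higher number from compound 1 to compound 2 (0.38 log units; beyond the scatter).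

Compound 4 relates to compound 3 by cyano in place of ethoxycarbonyl on an aromatic carbon. This is the same kind of change as that from compound 1 to compound 2, made on a core that differs by hydrogen in place of chloro on an aromatic carbon. The surroundings of the place are not identical: in compound 1 the ring atom two ring bonds away bears a (4-chlorophenyl)carbamoyl group, in compound 3 a phenylcarbamoyl group (9 heavy atoms). Since the chloro-to-hydrogen swap itself moved the number only within the scatter, that difference is not expected to alter the outcome of the cyano-for-ethoxycarbonyl step much.

For the measured compounds named here, the expectation for compound 4 therefore rests on the single measured instance of the change: a step of about the same size as a 2.4-fold higher number from compound 1 to compound 2 (0.38 log units; beyond the scatter), applied to compound 3 at 490 nM. The estimated step is a 2.3-fold higher number from compound 3 to compound 4 (0.37 log units; beyond the scatter). Compound 4 is estimated at 1150 nM in this assay, with a plausible range from 650 nM to 2100 nM.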

Compound 4, half-maximal inhibitory concentration: 8060 nM
Compound 4: the middle estimate sits 7.0-fold (0.85 log units) below what was measured; measured number above the stated range.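

Cyano in place of ethoxycarbonyl gives a 16-fold higher number from compound 3 to compound 4 (1.22 log units; beyond the scatter) in this assay, so the size of this step does not carry over unchanged from the core of compound 1 to the core of compound 3: the same change on two cores in this assay, a 2.4-fold higher number (0.38 log units; beyond the scatter) from compound 1 to compound 2 and a 16-fold higher number (1.22 log units; beyond the scatter) from compound 3 to compound 4, 6.8-fold (0.83 log units) apart, beyond the scatter of two such steps.

Read the other way, hydrogen in place of chloro gives a 7.8-fold higher number from compound 2 to compound 4 (0.89 log units; beyond the scatter) with cyano present, although the same swap stays within the scatter with ethoxycarbonyl present, so the two changes do not add up independently across these four compounds: the same change on two cores in this assay, a 1.1-fold higher number (0.06 log units; within the scatter) from compound 1 to compound 3 and a 7.8-fold higher number (0.89 log units; beyond the scatter) from compound 2 to compound 4, 6.8-fold (0.83 log units) apart, beyond the scatter of two such steps.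

For the compounds shown here, the direction of the cyano step holds on both cores, with the higher number each time, but each core supplies only one pair, and these pairs do not show why the sizes differ or what size the step would take on a further core.

The compounds shown leave open whether the large step follows from the arrival of cyano or the departure of ethoxycarbonyl, a question that a methyl ester, a carboxylic acid or a primary carboxamide at the same place could help to separate. From the compounds shown here alone, it also remains open whether the dependence on chloro extends to a fluoro or methoxy group on the ring of the phenylcarbamoyl group.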